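A few compounds are considered here, and "the series" means these few. Any claim that something is new, unique, unknown or untested is made for them only; others in the source may bear on it.

In a functional assay on Bel-7402 cells (Homo sapiens) for inhibition, read by MTT assay, with a stated time of 24 h, tested at 10 ug/mL (a lower number here means less inhibition of growth, a higher number more inhibition of growth at the concentration tested), compound 1 `O=C(CCCCC(S)CCS)Nc1ccc(F)cc1` gives 6.14% and compound 2 `COc1ccc(NC(=O)CCCCC(S)CCS)cc1` gives 10.4% as its reading, so compound 2 cannot be told apart from compound 1. Compound 3 `O=C(CCCCC(S)CCS)Nc1ccc([N+](=O)[O-])cc1` carries nitro in place of methoxy on an aromatic carbon, para to a large group (nitro in place of methoxy on an aromatic carbon). Nitro has not been measured here, and the one measured step that bears on this change is a swap of group on an aromatic carbon (a number 4.3 percentage points higher from compound 1 to compound 2 (within the scatter)). A step beyond the scatter is therefore not expected in this assay for now. The estimated step is small (a number 1.4 percentage points lower from compound 2 to compound 3 (within the scatter)). Compound 3 is expected to give 9% within a range of 1% to 20% in this estimate.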

Compound 3, percent growth inhibition at one concentration: 14.4%
The estimate for compound 3 lay 5.4 percentage points below the measured number; measured number inside the range.
By their numbers in this assay, from the lowest: compounds 1, 2 and 3 (each within the scatter of the next).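

Nitro on this aromatic carbon, para to a large group, does not separate from the earlier groups in this assay: the swap from methoxy gives (a number 4 percentage points higher from compound 2 to compound 3 (within the scatter)), and the swap from fluoro gives (a number 8.3 percentage points higher from compound 1 to compound 3 (within the scatter)). Fluoro, methoxy and nitro at this place therefore cannot be told apart, so this position has so far shown no step beyond the scatter. Nothing available accounts for these readings. As far as these compounds go, an amine or a carboxylic acid at this place remains open, as does whether any group here can move the reading beyond the scatter.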